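The source may hold more compounds than are shown below. What is called first, only, known or untested is meant among the compounds shown, and "the series" means these compounds.

Measured compounds in an assay for inhibition of Indoleamine 2,3-dioxygenase 1 (Homo sapiens), with a stated time of 1 h, tested at 10 uM; on this read-out higher numbers stand for more inhibition at the one concentration tested (going by the name of the read-out) and lower numbers for less inhibition:

- compound 1 `Oc1cccc(CNc2cc(Br)cc3[nH]ncc23)c1`: 45%
- compound 2 `OCc1ccc(CNc2cc(Br)cc3[nH]ncc23)cc1`: 45%
- compound 3 `Nc1cccc(CNc2cc(Br)cc3[nH]ncc23)c1`: 31%

Compound 3 stands lowest of the three numbers in this assay; compound 1 and compound 2 both sit higher by a margin that exceeds the scatter, and compound 1 and compound 2 themselves lie within the scatter of each other, so no order between those two is claimed.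

Among the compounds with values here, the only measured step that differs in one place is a number 14 percentage points lower from compound 1 to compound 3 (beyond the scatter), which shows the change from hydroxy to amino on the aromatic carbon costing a modest but real amount of inhibition.

Compound 4 `ONc1cccc(CNc2cc(Br)cc3[nH]ncc23)c1` is not yet measured. Relative to compound 3 it carries hydroxy in place of hydrogen on a nitrogen on an aromatic ring. Cut one bond further out, the change reads amino to hydroxyamino, so compound 4 in a sense reintroduces the hydroxy that compound 1 has and compound 3 lacks, though now attached to the nitrogen rather than to the ring carbon.

Within the data shown here, the single bearing step, from compound 1 to compound 3, was modest and downward on removing hydroxy. Adding hydroxy back, on the nitrogen, is expected to recover part of that loss rather than all of it, since the hydroxyamino arrangement has no measured precedent in the series. A modest upward step is therefore expected: a number 9 percentage points higher from compound 3 to compound 4 (within the scatter). Compound 4 is estimated at 40%, with a range of 25% to 55%.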

Compound 4, a percentage reported as inhibition, at one concentration (the size of the read-out at that concentration, not a potency): 53%
Compound 4: middle estimate off by 13 percentage points, on the low side; the measured number falls inside the stated range.
By their numbers in this assay, from the lowest: compound 3; then compounds 1, 2 and 4 (each within the scatter of the next).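

In this assay, hydroxy in place of hydrogen on the nitrogen on the aromatic ring gives a number 22 percentage points higher from compound 3 to compound 4 (beyond the scatter), so the loss at this position is not fixed once the ring carbon bears a nitrogen, which the earlier amino compound could not show. Hydroxyamino in place of hydroxy on the aromatic carbon gives a number 8 percentage points higher from compound 1 to compound 4 (within the scatter), so no order between these two groups can be claimed, and read with a number 14 percentage points lower from compound 1 to compound 3 (beyond the scatter), amino alone stands apart from both at this position. Nothing available on these compounds accounts for the rise on adding hydroxy to the nitrogen.

Still open, on these data alone, is whether the gain depends on the free hydroxy on that nitrogen or on any substituent there, a question that a methoxyamino or a methylamino group at the same place would address. Also open, as far as these compounds go, is how a carboxylic acid at this aromatic carbon would compare with hydroxy and hydroxyamino, and whether these single-concentration numbers would carry over to a measured potency.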